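Trimethoxyphenyl at the ring carbon: compound 4 in the series

A few compounds are considered here, and "the series" means these few. Any claim that something is new, unique, unknown or untested is made for them only; others in the source may bear on it.

Compound 1 `COc1ccc(-c2cn(-c3cccc(C(=O)/C=C/c4cc(OC)c(OC)c(OC)c4)c3)c(=O)[nH]2)cc1` is the reference point. Going by the values given here, in a functional assay on SW-620 cells (Homo sapiens) for inhibition (on this read-out lower numbers stand for stronger inhibition of growth and higher numbers for weaker inhibition of growth), compound 1 gives 450 nM, the lowest number among the three compounds measured so far. Compound 2 `COc1ccc(-c2cn(-c3cccc(C(=O)/C=C/c4ccc(O)c(OC)c4)c3)c(=O)[nH]2)cc1` gives 2500 nM in this assay, and compound 3 `O=C(/C=C/c1cccc(O)c1)c1cccc(-n2cc(-c3ccccc3)[nH]c2=O)c1` gives 2410 nM. Among the compounds with values here, the one step between compounds that differ in a single place is a 5.6-fold higher number from compound 1 to compound 2 (0.74 log units; beyond the scatter), which concerns the aryl group on the double-bonded chain carbon and leaves the rest of the molecule untouched. Compound 3 differs from compound 1 in two places, so its gap to compound 1 cannot be assigned to either one.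

Compound 4 `COc1cc(/C=C/C(=O)c2cccc(-n3cc(-c4cc(OC)c(OC)c(OC)c4)[nH]c3=O)c2)cc(OC)c1OC` carries the change (3,4,5-trimethoxyphenyl in place of 4-methoxyphenyl on an aromatic carbon). Within the data shown here, no measured step alters the group on this aromatic carbon of the five-membered aromatic ring with 2 nitrogen; the only single-place step on hand, from compound 1 to compound 2, acts on the other end of the molecule. The data therefore give no direction for this assay here, and the expectation is for a step of no more than the usual scatter. Compound 4 is estimated at 500 nM, within 150 nM to 1800 nM, which corresponds to an expected step of a 1.1-fold higher number from compound 1 to compound 4 (0.05 log units; within the scatter).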

Compound 4, concentration for 50% growth inhibition: 1030 nM
The estimate for compound 4 lay 2.1-fold (0.31 log units) below the measured number, within the range that was stated.
By their numbers in this assay, from the lowest: compound 1; then compound 4; then compounds 3 and 2 (each within the scatter of the next).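

In this assay, the group on the aromatic carbon of the five-membered aromatic ring with 2 nitrogen does affect the read-out: replacing 4-methoxyphenyl with 3,4,5-trimethoxyphenyl gives a 2.3-fold higher number from compound 1 to compound 4 (0.36 log units; beyond the scatter). Of the two groups compared at this place with all else unchanged, 4-methoxyphenyl therefore gives the lower number, so the larger group with more hydrogen-bond acceptors brings no gain here. With a 5.6-fold higher number from compound 1 to compound 2 (0.74 log units; beyond the scatter), each end of the molecule now has one single-place step from compound 1, both towards weaker inhibition of growth, and no measurement at hand offers an explanation for either step.

The compounds shown leave open whether the response at this aromatic carbon follows the number of methoxy groups, as a 3,4-dimethoxyphenyl there would help to test, or whether other groups, such as a phenyl bearing an amine or a carboxylic acid, would be tolerated. Going by these compounds, it also remains open whether the step seen with the 3,4,5-trimethoxyphenyl on the double-bonded chain carbon would carry over when a different aryl group occupies that end of the molecule.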